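This account rests on a few compounds, and the source may have more. Where it says the series, first, only, none or still open, it means among the compounds named here.

Compound 2 `Cc1cc(-c2ccco2)cn2c(CSCCc3ccccc3)cnc12` carries a furan-2-yl group on an aromatic carbon of the shared core, where compound 1 `C=Cc1ccc(-c2cc(C)c3ncc(CSCCc4ccccc4)n3c2)cc1` carries a 4-vinylphenyl group instead. In an ADME assay on HEL cells (Homo sapiens) for cytotoxicity, with a stated time of 3 days (on this read-out higher numbers stand for lower toxicity in this test and lower numbers for higher toxicity in this test), compound 1 gives 20 ug/mL. For compound 2 this assay reports only a limit, > 4 ug/mL, and not a number. The step that the limit leaves unreadable from compound 1 to compound 2 therefore has no readable size, because compound 2 sits at the limit of > 4 ug/mL in this assay, at which 1 of the 2 values shown sits. So compound 2 stands only as a floor on the read-out, with nothing more known about where its true value lies.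

Compound 3 `Cc1cc(N2CCCC2=O)cn2c(CSCCc3ccccc3)cnc12` differs from compound 2 by 2-oxopyrrolidin-1-yl in place of furan-2-yl on an aromatic carbon. Going by the values given here, no measured step involves a 2-oxopyrrolidin-1-yl group, and the single measured step is itself unreadable, so there is nothing to draw on beyond the two values shown. The step that the limit leaves unreadable from compound 2 to compound 3 is therefore expected to be small, with no clear direction. Compound 3 is estimated to give 20 ug/mL in this assay, within a range from 4 ug/mL to 100 ug/mL, and it may well again return only a limit.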

Compound 3, minimum cytotoxic concentration: > 100 ug/mL
Compound 3: no number, only a limit; the forecaster's own chance of this, stated with the estimate: 50%; middle value at least 5.0-fold (0.69 log units) away from the limit.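

Placing 2-oxopyrrolidin-1-yl instead of 4-vinylphenyl on this aromatic carbon gives the first readable step in this assay, which is an at least 5.0-fold higher number from compound 1 to compound 3 (0.69 log units; beyond the scatter), so here a higher number stands for lower toxicity in the test. This shows that the position tolerates a five-membered non-aromatic ring carrying a carbonyl, and that the group on this carbon can move the read-out by more than the usual scatter of repeated measurements. The result for compound 3, > 100 ug/mL, is a limit and not a number, as is the result for compound 2, so the steps that involve compound 2 cannot be read, and the furan-2-yl group cannot yet be ranked against either of the other two groups.

The compounds shown leave open how far the true value of compound 3 lies from its limit, and whether the ring itself or its carbonyl goes with the change in the read-out. They also leave open how a morpholine ring, a simple amine or a carboxylic acid on this same aromatic carbon would read in this assay.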